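The compounds below may be only part of what the source reports. "The series", "measured", "known", "first", "only" and "open" are said of these compounds alone.

Measured so far in a functional assay on NCI-H322M cells (Homo sapiens) for inhibition, read by sulforhodamine B assay, with a stated time of 48 h; on this read-out lower numbers stand for stronger inhibition of growth and higher numbers for weaker inhibition of growth: compound 2 `O=C(Nc1cccc(-n2cc(-c3ccncc3)c(-c3ccc(Cl)c(O)c3)n2)c1)Nc1ccc(Cl)c(Cl)c1` gives 2890 nM; compound 1 `COc1cc(-c2nn(-c3cccc(NC(=O)Nc4ccc(Cl)c(Cl)c4)c3)cc2-c2ccncc2)ccc1Cl` gives 1690 nM; compound 3 `O=C(Nc1cccc(-n2cc(-c3ccncc3)c(-c3ccc(Cl)c(O)c3)n2)c1)Nc1cc(C(F)(F)F)cc(C(F)(F)F)c1` gives 1310 nM.

Compound 2 has the highest number of the three, though it sits within the scatter of compound 1 and apart from compound 3 only just beyond it. For the measured compounds named here, the only single-point step seen, a 1.7-fold higher number from compound 1 to compound 2 (0.23 log units; within the scatter), concerns the oxygen on the other end of the molecule and says nothing direct about the urea end. Compound 4 `O=C(Nc1cccc(-n2cc(-c3ccncc3)c(-c3ccc(Cl)c(O)c3)n2)c1)Nc1ccc(Cl)c(C(F)(F)F)c1` changes that urea end: trifluoromethyl in place of chloro on an aromatic carbon. Going by the values given here, no measured step covers this exact swap; compound 3 carries two trifluoromethyl groups on that ring and shows a lower number than compound 2, which hints, weakly, at a modest drop. The step is expected to be a 1.4-fold lower number from compound 2 to compound 4 (0.16 log units; within the scatter), so compound 4 is estimated at 2000 nM, between 900 nM and 4500 nM.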

Compound 4, concentration for 50% growth inhibition: 1090 nM
The estimate for compound 4 lay 1.8-fold (0.26 log units) above the measured number; low and high end bracket the measured number.
By their numbers in this assay, from the lowest: compounds 4, 3, 1 and 2 (each within the scatter of the next, the first and the last beyond it).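

On the urea's 3,4-dichlorophenyl end, trifluoromethyl in place of chloro gives a 2.7-fold lower number from compound 2 to compound 4 (0.42 log units; beyond the scatter), the only single-place change shown at this position. Growth inhibition therefore responds to what sits on this aromatic carbon, whereas the one earlier single-place step, at the other end of the molecule, stayed within the scatter. Nothing available explains this step.

On these data alone, whether a nitrile or an amine on this carbon would give a similar step remains open. So does whether the same swap would give a similar step in compound 1, which carries a methyl on the oxygen.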